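Amine variation on the shared core of compound 3

A few compounds are considered here, and "the series" means these few. Any claim that something is new, unique, unknown or untested is made for them only; others in the source may bear on it.

compound 1 `N[C@H]1CC[C@H](Nc2c(C(=O)NCc3ccc(F)cc3)nc(Br)c3cccnc23)CC1`: 2000 nM
compound 2 `C[C@H](Nc1c(C(=O)NCc2ccc(F)cc2)nc(Br)c2cccnc12)c1ccccc1`: "not determined" (no result reported)
compound 3 `O=C(NCc1ccc(F)cc1)c1nc(Br)c2cccnc2c1N1CCNCC1`: 7000 nM

In a functional assay on MCF7 cells (Homo sapiens) for cytotoxicity, read by MTT assay, with a stated time of 72 h (a higher number here means a weaker inhibitor, a lower number a stronger inhibitor), compound 1 gives 2000 nM and compound 3 gives 7000 nM. For the measured compounds named here, compound 3 carries the highest of the two numbers, with compound 1 nearest, and the single measured step, a 3.5-fold higher number from compound 1 to compound 3 (0.54 log units; beyond the scatter), shows that swapping the amine group on this aromatic carbon shifts the number modestly and beyond the scatter. Compound 4 `CN(C)CCCNc1c(C(=O)NCc2ccc(F)cc2)nc(Br)c2cccnc12` differs from compound 3 in one place: (3-(dimethylamino)propyl)amino in place of piperazin-1-yl on an aromatic carbon. Going by the values given here, only that one step bears on the change, so a modest step in this assay toward a lower number is expected, with a range that spans both measured values. The estimate for compound 4 is 3500 nM, with a range of 1200 nM to 10000 nM, so that a step of a 2.0-fold lower number from compound 3 to compound 4 (0.30 log units; within the scatter) is expected.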

Compound 4, half-maximal inhibitory concentration: 7000 nM
Compound 4: the middle estimate sits 2.0-fold (0.30 log units) below what was measured; the measured number falls inside the stated range.
By their numbers in this assay, from the lowest: compound 1; then compounds 3 and 4 (each within the scatter of the next).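

In this assay, replacing the ring of piperazin-1-yl with the open chain of (3-(dimethylamino)propyl)amino at this aromatic carbon leaves the number in place (no change at the digits printed from compound 3 to compound 4 (within the scatter)). The ring-free amine therefore does not close the gap to the 4-aminocyclohexyl group on the same nitrogen-linked position (a 3.5-fold higher number from compound 1 to compound 4 (0.54 log units; beyond the scatter)). No measured evidence accounts for this ranking of the amines.

Open, going by these compounds, is whether a shorter 2-aminoethyl chain or a morpholine ring at this carbon would shift the number. Also open, on these data alone, is whether a primary amine at the end of the propyl chain would match the 4-aminocyclohexyl group.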